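The compounds below may be only part of what the source reports. "The series", "measured", "known", "first", "only" and "open" are said of these compounds alone.

Working notes on the series. In a functional assay on SMMC-7721 cells (Homo sapiens) for cytotoxicity, read by MTT assay, with a stated time of 24 h (on this read-out higher numbers stand for weaker inhibition and lower numbers for stronger inhibition), compound 1 (`CN1C/C(=C\c2cccnc2)C(=O)/C(=C/c2ccccc2F)C1`) gives 5420 nM. Within the data shown here, compound 2 (`CN1C/C(=C\c2cccnc2)C(=O)/C(=C/c2cc([N+](=O)[O-])ccc2F)C1`) gives 6170 nM, so compound 1 stands level with the only other measured compound, the step being a 1.1-fold higher number from compound 1 to compound 2 (0.06 log units; within the scatter).

Compound 3 (`CN1C/C(=C\c2ccncc2)C(=O)/C(=C/c2ccccc2F)C1`) keeps the rest of compound 1 and carries pyridin-4-yl in place of pyridin-3-yl on a double-bonded chain carbon bound to a double-bonded ring carbon.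

Among the measured compounds shown here, no measured step covers a change at this place. For the measured compounds named here, the only step available has nitro in place of hydrogen on an aromatic carbon, and it is indirect evidence at best: a 1.1-fold higher number from compound 1 to compound 2 (0.06 log units; within the scatter). It shows one substitution in this small set that stayed within the scatter, and it gives no direction for the change to compound 3. No step beyond the scatter is therefore expected in this assay, though two measured compounds make a thin basis and a wide range is warranted.

The expected step is a 1.1-fold lower number from compound 1 to compound 3 (0.04 log units; within the scatter). For compound 3 the estimated value is 5000 nM, with an expected range of 2200 nM to 11500 nM.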

Compound 3, half-maximal inhibitory concentration: 7000 nM
Compound 3: the middle estimate sits 1.4-fold (0.15 log units) below what was measured; low and high end bracket the measured number.
By their numbers in this assay, from the lowest: compounds 1, 2 and 3 (each within the scatter of the next).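

Among these compounds, the change from pyridin-3-yl to pyridin-4-yl, on a double-bonded chain carbon bound to a double-bonded ring carbon, gives the first reading at this place, and in this assay it comes out as a 1.3-fold higher number from compound 1 to compound 3 (0.11 log units; within the scatter). The two groups have the same atoms and the same counts under the structural comparison, differing only in how the pyridine ring is joined, and at this place the assay does not tell them apart; the series now has one step at the pyridine group and one on the fluorophenyl ring, a 1.1-fold higher number from compound 1 to compound 2 (0.06 log units; within the scatter), and neither leaves the scatter. Nothing measured on these compounds speaks to the reason for this result.

On these data alone, a single pair of pyridinyl groups says little about the place as a whole, so it remains open whether a plain phenyl, a pyridin-2-yl or a ring carrying an amine or a carboxylic acid would give a step beyond the scatter. Also open, as far as these compounds go, is whether pyridin-4-yl would behave the same way alongside the nitro group of compound 2, and whether the level reading seen here would hold in any other cell line.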